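Methoxy for methyl on the amide side chain

The source may hold more compounds than are shown below. What is called first, only, known or untested is meant among the compounds shown, and "the series" means these compounds.

Compound 1 `CC[C@@H](Nc1c(C#N)c(-c2ccc(-c3cccnc3C)cc2)nc2cnccc12)C(N)=O`: 1.9
Compound 2 `CCOc1ccccc1-c1ccc(-c2nc3cnccc3c(N[C@H](CC)C(N)=O)c2C#N)cc1`: 3
Compound 3 `CC[C@@H](Nc1c(C#N)c(-c2ccc(-c3ncccc3C)cc2)nc2cnccc12)C(N)=O`: 2

The three compounds share a core and differ only in the aromatic group at its far end. In a physicochemical assay for lipophilicity, read by HPLC, at pH 7.5 (on this read-out lower numbers stand for lower lipophilicity and higher numbers for higher lipophilicity), compound 2 gives 3 and stands highest of the three: the step of a number 1.00 log units lower from compound 2 to compound 3 (beyond the scatter) is beyond the scatter, as is the step of a number 1.10 log units higher from compound 1 to compound 2 (beyond the scatter), while compounds 1 and 3 sit within the scatter of each other a number 0.10 log units higher from compound 1 to compound 3 (within the scatter).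

Compound 4 `CCOc1ccccc1-c1ccc(-c2nc3cnccc3c(NC(COC)C(N)=O)c2C#N)cc1` keeps the 2-ethoxyphenyl of compound 2 and changes the chain on the amino nitrogen instead: 1-carbamoyl-2-methoxyethyl in place of 1-carbamoylpropyl on a nitrogen on an aromatic ring. Going by the values given here, none of the measured steps touches this position; all three concern the aromatic group on the other side of the core, so they give no direct guide to the change from compound 2 to compound 4. What the change counts is one more oxygen and one more hydrogen-bond acceptor in the entering group, with the same single donor. On that basis a drop of moderate size in this assay is expected, a number 0.60 log units lower from compound 2 to compound 4 (beyond the scatter), rather than no change. Compound 4 is therefore estimated at 2.4, within a range from 1.9 to 2.9.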

Compound 4, distribution coefficient: 2.8
Compound 4: the middle estimate sits 0.40 log units below what was measured; the measured number falls inside the stated range.
By their numbers in this assay, from the lowest: compounds 1 and 3 (each within the scatter of the next); then compounds 4 and 2 (each within the scatter of the next).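

At this position, the first one in the series to vary outside the far aromatic group, this assay gives a step of a number 0.20 log units lower from compound 2 to compound 4 (within the scatter) for 1-carbamoyl-2-methoxyethyl in place of 1-carbamoylpropyl on a nitrogen on an aromatic ring. Going by these compounds alone, the extra oxygen and extra hydrogen-bond acceptor counted in the entering group therefore leave compounds 2 and 4 indistinguishable on this read-out, whereas exchanging the aromatic group gave a step of a number 1.10 log units higher from compound 1 to compound 2 (beyond the scatter), although the comparison also spans the defined stereocentre of the leaving group, which has no counterpart in the entering group. Nothing measured here bears on why the read-out holds across this change.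

The compounds shown leave open whether the same exchange would behave alike with 2-methylpyridin-3-yl or 3-methylpyridin-2-yl in place of the 2-ethoxyphenyl, since this chain is compared only with 2-ethoxyphenyl present. They also leave open how this read-out would respond at the same nitrogen to a chain ending in an amine or a carboxylic acid, or to a longer chain such as 1-carbamoyl-3-methoxypropyl.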